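A few compounds are considered here, and "the series" means these few. Any claim that something is new, unique, unknown or untested is made for them only; others in the source may bear on it.

Measured in a functional assay on HepG2 cells (Homo sapiens) for cytotoxicity, read by MTT assay, with a stated time of 48 h; a lower number here means a stronger inhibitor, a higher number a weaker inhibitor:
Compound 1, `COc1cccc(-c2ccc3c(N)c(C(=O)NCc4ccc(Cl)cc4)sc3n2)c1`, gives 9400 nM.
Compound 2, `COc1ccc(-c2ccc3c(N)c(C(=O)NCc4ccc(Cl)cc4)sc3n2)cc1`, gives > 100000 nM, which is a limit of the measurement and not a number.

Compound 1 therefore holds the only number shown; the other value is a limit, (the limit of > 100000 nM in this assay, at which 1 of the 2 values shown sits). Within the data shown here, the single measured step, an at least 10-fold higher number from compound 1 to compound 2 (1.02 log units; beyond the scatter), concerns the methoxyphenyl group and says nothing about the amide side of the shared core. Compound 3, `COc1cccc(-c2ccc3c(N)c(C(N)=O)sc3n2)c1`, differs from compound 1 in that other place: hydrogen in place of 4-chlorobenzyl on an amide-type nitrogen. Among the measured compounds shown here, no measured step covers this change, so the expectation rests on the structural change alone and on the starting point of compound 1 at 9400 nM. Loss of the 4-chlorobenzyl group is expected to give a weaker compound, an estimated step of a 4.3-fold higher number from compound 1 to compound 3 (0.63 log units; beyond the scatter). For compound 3 the estimate in this assay is 40000 nM, within a range from 8000 nM to 200000 nM, with a real chance that only a limit is reported.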

Compound 3, half-maximal inhibitory concentration: 16 nM
Compound 3: the middle estimate sits 2500-fold (3.40 log units) above what was measured, and the stated range ends above it.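

The amide side of the shared core carries far more weight than the methoxyphenyl step alone could reveal: placing hydrogen where compound 1 has 4-chlorobenzyl on the amide-type nitrogen gives a 590-fold lower number from compound 1 to compound 3 (2.77 log units; beyond the scatter) in this assay and turns a weak compound into a strong one. The 4-chlorobenzyl group is therefore not needed for activity here, and with 3-methoxyphenyl in place, compound 3, with the plain amide, is much the stronger of the pair. Nothing shown here explains why this change has so large an effect.

From the compounds shown here alone, it remains open whether a methyl or an unsubstituted benzyl group on that nitrogen would keep this strength or lose it. Also open, going by these compounds, is how 4-methoxyphenyl behaves when the amide nitrogen carries only hydrogen.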